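Removing a Methoxy Group: Small Steps in Macrophage Cytotoxicity

The source may hold more compounds than are shown below. What is called first, only, known or untested is meant among the compounds shown, and "the series" means these compounds.

Three compounds have been measured in an ADME assay on RAW264.7 cells (Mus musculus) for cytotoxicity, read by MTT assay, with a stated time of 24 h, tested at 5 ug/mL; a higher number here means a weaker effect of the compound at the concentration tested, a lower number a stronger effect:
compound 1 `COc1ccc(C(=O)/C=C/c2ccc(OC)c(OC)c2)c(O)c1` gives 73.9%
compound 2 `COc1ccc(C(=O)/C=C/c2ccc(OC)c(OC)c2OC)c(O)c1` gives 72.5%
compound 3 `COc1ccc(C(=O)CCc2ccc(OC)c(OC)c2)c(O)c1` gives 75.2%

Compound 1 and compound 2 share a core and differ in one place only: hydrogen in place of methoxy on an aromatic carbon. That change gave a number 1.4 percentage points higher from compound 2 to compound 1 (within the scatter), so the two numbers cannot be told apart. The number for compound 3 lies within the scatter of both compound 1 and compound 2, so none of the three can be called weaker or stronger than another. The difference between the core of compound 3 and the core of compound 2 is not broken down here.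

Compound 4 `COc1ccc(CCC(=O)c2ccc(OC)cc2O)cc1` has not yet been measured in this assay. It differs from compound 3 by hydrogen in place of methoxy on an aromatic carbon. Going by the values given here, this is the same kind of change as the one from compound 2 to compound 1, but the surroundings differ: in compound 2 the methoxy that leaves sits ortho to a large group, ortho to a methoxy group and meta to a methoxy group, whereas in compound 3 it sits ortho to a methoxy group and meta to a large group. Among the compounds with values here, only one earlier example of this change exists, and it moved the number by a number 1.4 percentage points higher from compound 2 to compound 1 (within the scatter). On that basis the step from compound 3 to compound 4 is expected to be small, a number 0.2 percentage points lower from compound 3 to compound 4 (within the scatter). Compound 4 is therefore expected to give about 75% in this assay, with a range from 66% to 84%.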

Compound 4, a percentage reported as activity, at one concentration (the size of the read-out at that concentration, not a potency): 92.3%
For compound 4 the middle estimate is 17.3 percentage points below the measured one; measured number outside the range, above it.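

In this assay, replacing a methoxy group with hydrogen on compound 3 gave a number 17.1 percentage points higher from compound 3 to compound 4 (beyond the scatter), which means a weaker effect at the single concentration tested. The same replacement therefore did not give a step of the same size on the two cores: the same change on two cores in this assay, a number 1.4 percentage points higher (within the scatter) from compound 2 to compound 1 and a number 17.1 percentage points higher (beyond the scatter) from compound 3 to compound 4, 15.7 percentage points apart, beyond the scatter of two such steps So, in this series, the step seen on one core cannot be carried to another as a fixed amount, although two examples do not show which difference in the surroundings of the methoxy group or in the cores sets the size of the step, and a read-out at one concentration is not a potency.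

The compounds shown leave open whether a large step would appear on a third core, or whether it belongs to the methoxy group that leaves on compound 3 alone. They also leave open what other groups would do at that same aromatic carbon, such as a fluorine atom, an ethoxy group or an amine, and so whether hydrogen itself matters or only the loss of the methoxy group.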